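Chloro in place of fluoro on an aromatic carbon

The compounds below may be only part of what the source reports. "The series", "measured", "known", "first", "only" and "open" are said of these compounds alone.

Values measured in a functional assay on Caco-2 cells (Homo sapiens) for inhibition, read by MTT assay, with a stated time of 48 h (on this read-out higher numbers stand for weaker inhibition of growth and lower numbers for stronger inhibition of growth), for three compounds:
Compound 1 `CN1CC[C@H](c2c(O)cc(O)c3c(=O)cc(/C=C/c4ccc(Cl)cc4)oc23)[C@H](O)C1` gives 5600 nM
Compound 2 `CN1CC[C@H](c2c(O)cc(O)c3c(=O)cc(/C=C/c4cccc(F)c4)oc23)[C@H](O)C1` gives 8000 nM
Compound 3 `CN1CC[C@H](c2c(O)cc(O)c3c(=O)cc(/C=C/c4ccccc4F)oc23)[C@H](O)C1` gives 7000 nM

Compound 3 cannot be separated from the other two compounds: a 1.1-fold lower number from compound 2 to compound 3 (0.06 log units; within the scatter) and a 1.3-fold higher number from compound 1 to compound 3 (0.10 log units; within the scatter) both lie within the scatter. Compound 4 `CN1CC[C@H](c2c(O)cc(O)c3c(=O)cc(/C=C/c4ccccc4Cl)oc23)[C@H](O)C1` keeps the shared core and differs from compound 3 in one place, chloro in place of fluoro on an aromatic carbon with chloro in place of fluoro on an aromatic carbon, ortho to a large group.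

For the measured compounds named here, no measured step makes this exact exchange. The nearest evidence comes from the steps that exchange 4-chlorophenyl for a fluorophenyl group, a 1.4-fold higher number from compound 1 to compound 2 (0.15 log units; within the scatter) and a 1.3-fold higher number from compound 1 to compound 3 (0.10 log units; within the scatter), and both are within the scatter. Moving the fluoro group, in a 1.1-fold lower number from compound 2 to compound 3 (0.06 log units; within the scatter), also stays within it. In this assay the expected result is therefore no step beyond the scatter, and the estimated step is a 1.1-fold lower number from compound 3 to compound 4 (0.03 log units; within the scatter) in size.

For compound 4 the estimated value is 6500 nM with an expected range from 3500 nM to 12000 nM as its limits.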

Compound 4, concentration for 50% growth inhibition: 9000 nM
The estimate for compound 4 lay 1.4-fold (0.14 log units) below the measured number, within the range that was stated.
By their numbers in this assay, from the lowest: compounds 1, 3, 2 and 4 (each within the scatter of the next).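

In this assay, the exchange of fluoro for chloro on an aromatic carbon, ortho to a large group, now has a direct reading: a 1.3-fold higher number from compound 3 to compound 4 (0.11 log units; within the scatter) shows that this change, too, stays within the scatter. The 2-chlorophenyl group also cannot be separated from the 3-fluorophenyl group, a 1.1-fold higher number from compound 2 to compound 4 (0.05 log units; within the scatter), or from the 4-chlorophenyl group, a 1.6-fold higher number from compound 1 to compound 4 (0.21 log units; within the scatter), so neither the choice between these two halogens nor their placing in these compounds distinguishes any of the four. Nothing available here explains why these values stay so close.

The compounds shown leave open whether a group of another kind in the same place, such as an amine, a carboxylic acid or a methoxy group, would give a step beyond the scatter. They also leave open how the parent phenyl group, with no halogen, would compare with these four.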